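A few compounds are considered here, and "the series" means these few. Any claim that something is new, unique, unknown or untested is made for them only; others in the source may bear on it.

Of the compounds shown here, three have been measured in an ADME assay on HepG2 cells (Homo sapiens) for cytotoxicity, read by luminescence, CellTiter-Glo and ATP content, with a stated time of 72 h; on this read-out higher numbers stand for an effect only at larger amounts of compound and lower numbers for an effect already at smaller amounts. Compound 1 `COc1cccc(CNCCCNc2ccnc3cc(Oc4cccc(N(C)C)c4)ccc23)c1O` gives 7300 nM, compound 2 `COc1cccc(CNCCCNc2ccnc3cc(-c4cccc5ccccc45)ccc23)c1O` gives 2520 nM, and compound 3 `COc1cccc(CNCCCNc2ccnc3cc(CC(C)C)ccc23)c1O` gives 2920 nM. Compound 3 stands second highest of the three: the step of a 2.5-fold lower number from compound 1 to compound 3 (0.40 log units; beyond the scatter) is beyond the scatter, while a 1.2-fold higher number from compound 2 to compound 3 (0.06 log units; within the scatter) lies within it. Compound 4 `COc1cccc(CNCCCNc2ccnc3cc(C4CCCCC4)ccc23)c1O` carries cyclohexyl in place of isobutyl on an aromatic carbon. The step that bears most on this change is a 1.2-fold higher number from compound 2 to compound 3 (0.06 log units; within the scatter), where naphthalen-1-yl and isobutyl on the same aromatic carbon give numbers within the scatter of each other; a 2.9-fold lower number from compound 1 to compound 2 (0.46 log units; beyond the scatter) and a 2.5-fold lower number from compound 1 to compound 3 (0.40 log units; beyond the scatter) show only that 3-(dimethylamino)phenoxy stands apart. In this assay the expected step is therefore a 1.0-fold lower number from compound 3 to compound 4 (0.02 log units; within the scatter), which lies within the scatter. Compound 4 is estimated at 2800 nM, with a range of 1300 nM to 6000 nM.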

Compound 4, half-maximal effective concentration: 1080 nM
For compound 4 the middle estimate is 2.6-fold (0.41 log units) above the measured one, outside the stated range (below it).
By their numbers in this assay, from the lowest: compound 4; then compounds 2 and 3 (each within the scatter of the next); then compound 1.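

In this assay this aromatic carbon no longer looks indifferent to the carbon group it carries: a 2.7-fold lower number from compound 3 to compound 4 (0.43 log units; beyond the scatter) and a 2.3-fold lower number from compound 2 to compound 4 (0.37 log units; beyond the scatter) both lie beyond the scatter, whereas compound 2 and compound 3 could not be separated. Among these compounds, with a 6.8-fold lower number from compound 1 to compound 4 (0.83 log units; beyond the scatter) as the widest step so far, the cyclohexyl of compound 4 goes with the lowest number of the four. The data shown offer no explanation for this difference. From the compounds shown here alone, whether cyclopentyl, cycloheptyl, or a six-membered ring bearing an amine or a carboxylic acid would follow cyclohexyl remains open.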